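Compound 1 gives up its 5-(furan-2-yl)-1H-pyrazol-3-yl group

The source may hold more compounds than are shown below. What is called first, only, known or untested is meant among the compounds shown, and "the series" means these compounds.

Compound 1 `O=C1/C(=C\Nc2cc(-c3ccco3)[nH]n2)C(c2ccccc2)=NN1c1ccccc1`: 12400 nM
Compound 2 `O=C1/C(=C\Nc2cc(-c3ccccc3)[nH]n2)C(c2ccccc2)=NN1c1ccccc1`: 8750 nM

Both values come from a functional assay on MDA-MB-453 cells (Homo sapiens) for antiproliferative activity, read by MTT assay, with a stated time of 72 h; a higher number here means a weaker inhibitor, a lower number a stronger inhibitor. There, compound 1 at 12400 nM lies within the scatter of compound 2 at 8750 nM. Compound 3 `CSC[C@H](N/C=C1\C(=O)N(c2ccccc2)N=C1c1ccccc1)C(=O)O` differs from compound 1 on the amine nitrogen: 1-carboxy-2-(methylsulfanyl)ethyl in place of 5-(furan-2-yl)-1H-pyrazol-3-yl on an amine nitrogen. Going by the values given here, the only measured step, a 1.4-fold lower number from compound 1 to compound 2 (0.15 log units; within the scatter), changes just the furan-2-yl part of the departing group, so it says little here. Among the compounds with values here, no measured compound lacks that whole group. A modest move towards a higher number is therefore expected, with wide uncertainty. The expected change is a 1.6-fold higher number from compound 1 to compound 3 (0.21 log units; within the scatter). For compound 3 the estimated value is 20000 nM, with an expected range of 6000 nM to 70000 nM.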

Compound 3, half-maximal inhibitory concentration: 9460 nM
The estimate for compound 3 lay 2.1-fold (0.33 log units) above the measured number; measured number inside the range.
By their numbers in this assay, from the lowest: compounds 2, 3 and 1 (each within the scatter of the next).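

The step in this assay of a 1.3-fold lower number from compound 1 to compound 3 (0.12 log units; within the scatter) shows that this amine nitrogen tolerates more than a change to the furan-2-yl part: the whole 5-(furan-2-yl)-1H-pyrazol-3-yl group can be exchanged for 1-carboxy-2-(methylsulfanyl)ethyl, which has no ring, with the values staying within the scatter. No measurement available here explains this result. The compounds shown leave open how a methyl ester in place of the carboxylic acid, a plain alkyl chain in place of the methylsulfanyl group, or the opposite configuration at the stereocentre would read in this assay. These parts entered together, so their separate contributions cannot be told apart.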